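The source may report more compounds than this note shows. Statements on the series, on what has been measured and on what is new or still open speak of the compounds shown alone.

Among the compounds with values here, compound 1 `CC(C)(C)c1cc(NC(=O)Nc2cc(C(F)(F)F)cc(C(F)(F)F)c2)n(-c2ccccc2)n1` is the weakest stabiliser among the three measured compounds: in an assay on isolated protein for inhibition of STE20-like serine/threonine-protein kinase (Homo sapiens), read by thermal shift assay, tested at 10 uM (on this read-out higher numbers stand for stronger stabilisation of the target against heat and lower numbers for weaker stabilisation of the target), compound 1 gives 0 degrees C. Compound 2 `CC(C)(C)c1cc(NC(=O)Nc2ccc(F)c(F)c2)n(-c2ccccc2)n1` gives 5.5 degrees C, and compound 3 `CC(C)(C)c1cc(NC(=O)Nc2ccccc2)n(-c2ccccc2)n1` gives 7.7 degrees C. The one step that joins two measured compounds directly, a number 2.2 degrees C higher from compound 2 to compound 3 (beyond the scatter), changes the ring attached to the urea, not the phenyl on the shared core.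

Compound 4 `Cc1ccc(-n2nc(C(C)(C)C)cc2NC(=O)Nc2cc(C(F)(F)F)cc(C(F)(F)F)c2)cc1` differs from compound 1 in one place: methyl in place of hydrogen on an aromatic carbon. Read one bond further out, this is phenyl becoming 4-methylphenyl, on the ring that carries the shared core rather than the urea. No measured step touches that ring, so nothing shown tells how a methyl there moves the shift of the melting temperature. A single added carbon is a small change, and the starting point of compound 1 is already at the bottom of the measured range.

The estimate for compound 4 is therefore a number close to that of compound 1, 0.5 degrees C, between -1.5 degrees C and 3 degrees C, which means an expected step of a number 0.50 degrees C higher from compound 1 to compound 4 (within the scatter), not beyond the scatter.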

Compound 4, shift of the target's melting temperature: 0 degrees C
Beside the measured number, compound 4's estimate is 0.50 degrees C above it; the range from low to high includes it.
By their numbers in this assay, from the lowest: compounds 1 and 4 (each within the scatter of the next); then compound 2; then compound 3.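

In this assay, turning phenyl into 4-methylphenyl gives no change at the digits printed from compound 1 to compound 4 (within the scatter), and this is the only reading shown of a change on the ring carried by the shared core. Compound 4 therefore gains no measurable stabilisation from the methyl, yet compound 1 has no shift to lose, so this pair cannot reveal whether the methyl would lower a shift that was there to begin with. Nothing shown offers an explanation for this result.

Going by these compounds, it stays open whether the same methyl would move the number on a more stabilising compound such as compound 3, which gives 7.7 degrees C. Also open is what other groups in this place on the ring, such as a methoxy group or an amine, would do.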